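Removing a methoxy group: two measured, one expected

The compounds below may be only part of what the source reports. "The series", "measured", "known", "first", "only" and "open" are said of these compounds alone.

Of the compounds shown here, three have been measured in a functional assay on IMR-32 cells (Homo sapiens) for cytotoxicity, read by sulforhodamine B assay, with a stated time of 48 h; a lower number here means a stronger inhibitor, a higher number a weaker inhibitor. Compound 1 `COc1ccc(C2CC(c3cccc4ccccc34)=NN2C(C)=O)cc1OC` gives 1680 nM. Compound 2 `COc1ccc(C2CC(c3cccc4ccccc34)=NN2C(C)=O)cc1` gives 4990 nM in this assay. Compound 3 `COc1ccc(C2CC(c3ccc4ccccc4c3)=NN2CC=O)c(OC)c1OC` gives 780 nM in this assay, the lowest number of the three; its steps to compound 1 and to compound 2 are both beyond the scatter. The difference between the core of compound 1 and the core of compound 3 is not broken down here.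

The change from compound 1 to compound 2 is hydrogen in place of methoxy on an aromatic carbon and it made a step of a 3.0-fold higher number from compound 1 to compound 2 (0.47 log units; beyond the scatter).

Compound 4 `COc1ccc(C2CC(c3ccc4ccccc4c3)=NN2CC=O)cc1OC` has not yet been measured. It differs from compound 3 by hydrogen in place of methoxy on an aromatic carbon. Among the measured compounds shown here, this is the same kind of change as the one between compound 1 and compound 2, but not the same: in compound 3 the leaving methoxy stands ortho to a large group, ortho to a methoxy group and meta to a methoxy group, whereas in compound 1 it stood ortho to a methoxy group and meta to a large group. For the measured compounds named here, only one measured step of this kind is available, and it comes from a different core.

The expectation rests on that single step, a 3.0-fold higher number from compound 1 to compound 2 (0.47 log units; beyond the scatter), read as a weaker inhibitor upon loss of the methoxy, with a wider range to allow for the different surroundings and core. Compound 4 is expected to show a step of a 2.6-fold higher number from compound 3 to compound 4 (0.41 log units; beyond the scatter) in this assay. Compound 4 is estimated at 2000 nM in this assay, with a likely range from 900 nM to 5000 nM.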

Compound 4, half-maximal inhibitory concentration: 1590 nM
Beside the measured number, compound 4's estimate is 1.3-fold (0.10 log units) above it, and the stated range covers the measured number.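

In this assay, hydrogen in place of methoxy on an aromatic carbon gives a 2.0-fold higher number from compound 3 to compound 4 (0.31 log units; beyond the scatter), so this loss of a methoxy group again goes with a weaker inhibitor, as it did on the core of compound 1. The change therefore carries across these two cores in direction, and its size does not differ beyond what two such steps would scatter: the same change on two cores in this assay, a 3.0-fold higher number (0.47 log units; beyond the scatter) from compound 1 to compound 2 and a 2.0-fold higher number (0.31 log units; beyond the scatter) from compound 3 to compound 4, 1.5-fold (0.16 log units) apart, within the scatter of two such steps. Among the compounds shown here, this rests on only two pairs, with the methoxy leaving from different surroundings on each core, so it shows neither a rule for other cores or other ring positions nor any reason for the step.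

Every compound shown has only methoxy or hydrogen at the varied ring positions, which leaves open how a hydroxy group, a chlorine atom or an amine at the same place would compare with the methoxy. Also open, as far as these compounds go, is how the number would move if a further methoxy group were replaced by hydrogen on the core of compound 3, and whether a longer alkoxy chain in place of the methoxy would keep the number of compound 3.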